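Thiophene for Phenyl Across Two Linker Lengths

The source may report more compounds than this note shows. Statements on the series, on what has been measured and on what is new or still open speak of the compounds shown alone.

Measured compounds:
Compound 1 `CCOc1cc(NC(=O)CCCCCC(=O)Nc2cc(-c3ccccc3)ccc2N)cc2c1OCC([N+](=O)[O-])=C2` gives 3210 nM in a functional assay on K562 cells (Homo sapiens) for antiproliferative activity, read by MTT assay, with a stated time of 48 h; on this read-out higher numbers stand for weaker inhibition of growth and lower numbers for stronger inhibition of growth.
Compound 2 `CCOc1cc(NC(=O)CCCCCCC(=O)Nc2cc(-c3ccccc3)ccc2N)cc2c1OCC([N+](=O)[O-])=C2` gives 2000 nM in this assay.
Compound 3 `CCOc1cc(NC(=O)CCCCCCC(=O)Nc2cc(-c3ccc(C)s3)ccc2N)cc2c1OCC([N+](=O)[O-])=C2` gives 3110 nM in this assay.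

Among the compounds with values here, all three numbers lie close together, and no step among them is beyond the scatter, so none of the three can be called stronger or weaker than another. Compound 2 and compound 3 share one core and differ in a single place: 5-methylthiophen-2-yl in place of phenyl on an aromatic carbon. That change produced a 1.6-fold higher number from compound 2 to compound 3 (0.19 log units; within the scatter). Compound 1 and compound 2 carry different cores; the difference between the two cores is not broken down here.

Compound 4 `CCOc1cc(NC(=O)CCCCCC(=O)Nc2cc(-c3ccc(C)s3)ccc2N)cc2c1OCC([N+](=O)[O-])=C2` has not yet been measured. It is built from compound 1 by the same change that led from compound 2 to compound 3: 5-methylthiophen-2-yl in place of phenyl on an aromatic carbon. The place lines of the two changes agree word for word, so this is the same change made on the other core.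

Within the data shown here, on the single precedent, compound 3 against compound 2, the change left the number within the scatter of its starting point, so for compound 4 an equally small step, a 1.4-fold higher number from compound 1 to compound 4 (0.15 log units; within the scatter), is expected in this assay, resting on a 1.6-fold higher number from compound 2 to compound 3 (0.19 log units; within the scatter) and on the starting value of compound 1, 3210 nM. Compound 4 is therefore estimated at 4500 nM, with a likely range from 2200 nM to 9500 nM.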

Compound 4, concentration for 50% growth inhibition: 2920 nM
Compound 4: middle estimate off by 1.5-fold (0.19 log units), on the high side, within the range that was stated.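

In this assay, putting 5-methylthiophen-2-yl in place of phenyl on the core of compound 1 gave a 1.1-fold lower number from compound 1 to compound 4 (0.04 log units; within the scatter), so on this core too the change left the number within the scatter of its starting point. Set beside the earlier pair, the change behaves alike on both cores, with no difference that can be told apart from the scatter: the same change on two cores in this assay, a 1.6-fold higher number (0.19 log units; within the scatter) from compound 2 to compound 3 and a 1.1-fold lower number (0.04 log units; within the scatter) from compound 1 to compound 4, 1.7-fold (0.23 log units) apart, within the scatter of two such steps. This shows that, in these two pairs and in this one assay, the exchange carries from one core to the other without a readable effect on growth inhibition; it does not show that the change strengthens or weakens growth inhibition on either core, and two pairs give no rule for cores beyond these.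

The compounds shown leave open whether a group other than these two on that aromatic carbon, such as an unsubstituted thiophen-2-yl, a pyridyl ring or a carboxylic acid, would move the number beyond the scatter. They also leave open whether the same small step would hold on a core with a longer chain.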